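Methoxycarbonyl added to the core of a urea-bearing benzimidazole series

This account rests on a few compounds, and the source may have more. Where it says the series, first, only, none or still open, it means among the compounds named here.

Compound 1 `CCCn1c(SCc2cc([N+](=O)[O-])ccc2OC)nc2cc(NC(=O)NC(C)(C)C)ccc21` gives 120 nM in an assay on isolated protein for inhibition of Gonadotropin-releasing hormone receptor (Rattus norvegicus); a higher number here means a weaker inhibitor, a lower number a stronger inhibitor. Compound 2 `COc1ccc([N+](=O)[O-])cc1CSc1nc2cc(NC(=O)NC(C)(C)C)ccc2n1Cc1ccncc1` gives 240 nM and compound 3 `COc1ccc([N+](=O)[O-])cc1CSc1nc2cc(NC(=O)NC(C)(C)C)ccc2n1C(C)C` gives 62 nM, so compound 1 sits among the three with a 2.0-fold higher number from compound 1 to compound 2 (0.30 log units; within the scatter) and a 1.9-fold lower number from compound 1 to compound 3 (0.29 log units; within the scatter), both within the scatter; only a 3.9-fold lower number from compound 2 to compound 3 (0.59 log units; beyond the scatter) exceeds it. Compound 4 `CCCn1c(SCc2cc([N+](=O)[O-])ccc2OC)nc2cc(NC(=O)NC(C)(C)C)cc(C(=O)OC)c21` carries methoxycarbonyl in place of hydrogen on an aromatic carbon. For the measured compounds named here, every measured step alters the group on the aromatic nitrogen, whereas this change sits on a ring carbon, so no measured step bears directly on it. Lacking such guidance, the author expects no change beyond the scatter, an estimated 1.1-fold higher number from compound 1 to compound 4 (0.03 log units; within the scatter). Compound 4 is therefore estimated at 130 nM, within 40 nM to 450 nM.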

Compound 4, half-maximal inhibitory concentration: 280 nM
Estimate against measurement, compound 4: 2.2-fold (0.33 log units) below, and the stated range covers the measured number.
By their numbers in this assay, from the lowest: compounds 3, 1, 2 and 4 (each within the scatter of the next, the first and the last beyond it).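

On this aromatic carbon, ortho to a fused ring, methoxycarbonyl in place of hydrogen gives a 2.3-fold higher number from compound 1 to compound 4 (0.37 log units; beyond the scatter) in this assay. This is the first change shown on a ring carbon rather than on the aromatic nitrogen, and it shows that a group here moves the number modestly beyond the scatter, toward a weaker inhibitor. Nothing available explains this shift. From the compounds shown here alone, it remains open whether a carboxylic acid, a methyl or a hydroxymethyl group on this carbon would match compound 4, and whether methoxycarbonyl has the same effect with isopropyl on the aromatic nitrogen, as in compound 3.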